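The source may hold more compounds than are shown below. What is called first, only, known or untested is meant among the compounds shown, and "the series" means these compounds.

Of the compounds shown here, three with a shared core have been measured in a functional assay on CHO-K1 cells for antagonist activity at C-X-C chemokine receptor type 3 (Homo sapiens), read by FLIPR and calcium flux; a lower number here means a stronger inhibitor, a higher number a weaker inhibitor. Compound 1 `C[C@@H]1CN(S(=O)(=O)C[C@]23CC[C@H](CC2=O)C3(C)C)CCN1c1ccc(C(F)(F)F)cn1` gives 501 nM, compound 2 `CC1(C)[C@@H]2CC[C@@]1(CS(=O)(=O)N1CCN(c3ccc(C(F)(F)F)c(Cl)n3)CC1)C(=O)C2` gives 251 nM, and compound 3 `CC1(C)[C@@H]2CC[C@@]1(CS(=O)(=O)N1CCN(c3ccc(C(F)(F)F)cn3)CC1)C(N)C2` gives 794 nM. Compound 3 therefore shows the highest number of the three, although the gap to compound 1 lies within the scatter, while the gap to compound 2 lies beyond it.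

Compound 4 `CCNC1C[C@H]2CC[C@]1(CS(=O)(=O)N1CCN(c3ccc(C(F)(F)F)cn3)CC1)C2(C)C` differs from compound 3 in one place: ethyl in place of hydrogen on an amine nitrogen. Going by the values given here, no measured pair shows the effect of this change, so the expected step from compound 3 to compound 4 is a 1.1-fold lower number from compound 3 to compound 4 (0.05 log units; within the scatter), which is no more than the scatter in either direction. For compound 4 the estimated value in this assay is 700 nM, with a range from 250 nM to 2000 nM.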

Compound 4, half-maximal inhibitory concentration: 7940 nM
The estimate for compound 4 lay 11-fold (1.05 log units) below the measured number; measured number outside the range, above it.
By their numbers in this assay, from the lowest: compounds 2, 1 and 3 (each within the scatter of the next, the first and the last beyond it); then compound 4.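

Ethyl in place of hydrogen on the amine nitrogen brings a 10-fold higher number from compound 3 to compound 4 (1.00 log units; beyond the scatter) in this assay and so moves the number well beyond the scatter. Going by these compounds alone, this is the first measured sign that this nitrogen does not accept every group, since the earlier compounds offered no single-place step. No measurement shown explains the change.

This one step leaves open whether methyl on the same nitrogen would raise the number as much as ethyl. From the compounds shown here alone, whether a longer chain such as propyl or an acetyl group would raise it further also remains unknown.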